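A few compounds are considered here, and "the series" means these few. Any claim that something is new, unique, unknown or untested is made for them only; others in the source may bear on it.

The measured compounds:
compound 1 `Cc1c(O)ccc2c1[C@H](Cn1cc(-c3ccccn3)nn1)[C@@]13CC(=O)[C@@](C)(CC[C@@H]21)C3`; in a functional assay on HL-60 cells (Homo sapiens) for cytotoxicity, read by MTT assay, with a stated time of 4 days (a lower number here means a stronger inhibitor, a higher number a weaker inhibitor), compound 1 gives > 20000 nM, which is a limit of the assay and not a number.
compound 2 `C=C1C(=O)[C@]23C[C@@]1(O)CC[C@H]2c1ccc(OS(=O)(=O)c2ccc(C)cc2)c(C)c1[C@@H]3Cn1cc(-c2ccc(F)cc2)nn1`; in this assay compound 2 gives 1290 nM.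
compound 3 `C=C1C[C@]23C[C@@]1(O)CC[C@H]2c1cc(Br)c(O)c(C)c1[C@@H]3Cn1cc(-c2ccc(OC)cc2)nn1`; in this assay compound 3 gives > 20000 nM, again a limit rather than a number.

Within the data shown here, compound 2 therefore holds the only real number among the three; the other two results are the limit of > 20000 nM in this assay, at which 2 of the 3 values shown sit. Compound 4 `C=C1C(=O)[C@]23C[C@@]1(O)CC[C@H]2c1ccc(OS(=O)(=O)c2ccc(C)cc2)c(C)c1[C@@H]3Cn1cc(-c2ccccn2)nn1` keeps the core of compound 2 and differs from it in one place: pyridin-2-yl in place of 4-fluorophenyl on an aromatic carbon. Among the measured compounds shown here, no two measured compounds differ in a single spot, so no measured step tells the size of this change. Compound 1 also carries pyridin-2-yl, but it differs from compound 2 in several further places, so its limit cannot be tied to that group alone. The expectation is a modest move toward weaker inhibition, perhaps no larger than the scatter, as the step of a 2.3-fold higher number from compound 2 to compound 4 (0.37 log units; beyond the scatter). Compound 4 is estimated at 3000 nM, within 800 nM to 15000 nM.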

Compound 4, half-maximal inhibitory concentration: 1810 nM
Estimate against measurement, compound 4: 1.7-fold (0.22 log units) above; the measured number falls inside the stated range.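

In this assay, replacing 4-fluorophenyl with pyridin-2-yl on the five-membered aromatic ring gives a 1.4-fold higher number from compound 2 to compound 4 (0.15 log units; within the scatter). This is the first single-change comparison among these compounds, and it leaves the two compounds indistinguishable. At this position, a six-membered aromatic ring with one ring nitrogen can therefore stand in for the fluorinated carbon ring with no change that can be read in this measurement.

As far as these compounds go, whether a carboxylic acid or an amine on that ring, or a longer alkyl chain in its place, would be tolerated remains open. Two results offer no number for comparison: the limit of > 20000 nM in this assay, at which 2 of the 4 values shown sit.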